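This account rests on a few compounds, and the source may have more. Where it says the series, first, only, none or still open, it means among the compounds named here.

Measured in an assay on isolated protein for inhibition of ubiquitin carboxyl-terminal hydrolase 7 (Homo sapiens), with stated times of 30 min and 2 h; a higher number here means a weaker inhibitor, a lower number a stronger inhibitor:
- compound 1, `Cn1nc2c(=O)n(CC3(O)CCN(Cc4ccc(-c5ccco5)cc4Cl)CC3)cnc2c1-c1ccc(CNC(=O)C(F)(F)F)cc1`, gives 2060 nM
- compound 2, `CC(C)NCc1ccc(-c2c3ncn(CC4(O)CCN(Cc5ccc(-c6ccco6)cc5Cl)CC4)c(=O)c3nn2C)cc1`, gives 29.1 nM
- compound 3, `Cn1nc2c(=O)n(CC3(O)CCN(Cc4ccc(-c5ccco5)cc4Cl)CC3)cnc2c1-c1ccc(CNC=O)cc1`, gives 20.9 nM

Compound 3 gives the lowest of the three numbers, but the step separating it from its nearest neighbour is a 1.4-fold lower number from compound 2 to compound 3 (0.14 log units; within the scatter), so the two cannot be ordered; only compound 1 stands apart, with a 99-fold lower number from compound 1 to compound 3 (1.99 log units; beyond the scatter) and a 71-fold lower number from compound 1 to compound 2 (1.85 log units; beyond the scatter).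

Compound 4, `Cn1nc2c(=O)n(CC3(O)CCN(Cc4ccc(-c5ccco5)cc4Cl)CC3)cnc2c1-c1ccc(Cl)cc1`, has not been measured. Relative to compound 3 the change is chloro in place of (formylamino)methyl on an aromatic carbon. The shared core and the substituted benzylpiperidinol side are untouched.

Which steps bear on this? All three measured steps alter the same position on the pendant phenyl ring, and they show that the group there is not neutral: the trifluoroacetamide of compound 1 sits far from the formamide of compound 3 and the isopropylamine of compound 2, while those two sit together. Chloro, however, removes both the hydrogen-bond donor and acceptor counted in the change, something none of the measured steps did, so no close precedent exists in this set. The expectation is a loss of some size in this assay, less severe than the step from compound 1, and the estimated step is a 5.7-fold higher number from compound 3 to compound 4 (0.76 log units; beyond the scatter). Compound 4 is thus expected at 120 nM, range 30 nM to 500 nM.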

Compound 4, half-maximal inhibitory concentration: 143 nM
For compound 4 the middle estimate is 1.2-fold (0.08 log units) below the measured one; the range from low to high includes it.
By their numbers in this assay, from the lowest: compounds 3 and 2 (each within the scatter of the next); then compound 4; then compound 1.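

In this assay, chloro on this aromatic carbon keeps inhibition measurable, so neither the amide nor the amine side chain is needed for it, although both outperform chloro: a 6.8-fold higher number from compound 3 to compound 4 (0.84 log units; beyond the scatter) and a 4.9-fold higher number from compound 2 to compound 4 (0.69 log units; beyond the scatter). The trifluoroacetylated side chain, however, does worse than chloro, with a 14-fold lower number from compound 1 to compound 4 (1.16 log units; beyond the scatter), so a longer side chain at this position is not better in itself, and this position can lie well on either side of chloro. The order at this position is therefore compound 3 and compound 2 together, then compound 4, then compound 1, and no measurement shown gives a reason for it.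

Chloro differs from the (formylamino)methyl and (isopropylamino)methyl groups in size and in hydrogen-bond donor and acceptor counts at once, so these compounds cannot show which of these differences accounts for the steps. An unsubstituted aminomethyl, a hydroxymethyl, a plain ethyl or a carboxylic acid on the same aromatic carbon would help to separate the contribution of the nitrogen from that of the chain, and a bromo or methyl group would show whether chloro itself matters.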